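A few compounds are considered here, and "the series" means these few. Any claim that something is new, unique, unknown or untested is made for them only; others in the source may bear on it.

Compound 1 `CC1CCN(C2CCN(S(=O)(=O)c3ccc(OC(F)(F)F)cc3)CC2)CC1`: > 5000 nM
Compound 2 `CCCCOc1ccc(S(=O)(=O)N2CCC(N3CCC(C)CC3)CC2)cc1`: > 5000 nM

In an ADME assay on HCT-116 cells (Homo sapiens) for cytotoxicity, read by CellTiter-Glo, with a stated time of 72 h (on this read-out higher numbers stand for weaker inhibition and lower numbers for stronger inhibition), compound 2 gives > 5000 nM as its reading, and this is a limit of the assay, not a number. Compound 1 likewise gives > 5000 nM as its reading, which is also a limit. Compound 2 therefore stands at the limit of > 5000 nM in this assay, at which 2 of the 2 values shown sit, and has no number to start from.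

For the measured compounds named here, the only measured step is a step that the two limits leave unreadable from compound 1 to compound 2, in which butyl takes the place of trifluoromethyl on an oxygen on an aromatic ring. It offers no size to carry forward.

Compound 3 `CC1CCN(C2CCN(S(=O)(=O)c3ccc(C(C)(C)C)cc3)CC2)CC1` has not yet been measured. Its change from compound 2 is tert-butyl in place of butoxy on an aromatic carbon, in words tert-butyl in place of butoxy on an aromatic carbon.

Since compound 1 and compound 2 both sit at the limit of > 5000 nM in this assay, at which 2 of the 2 values shown sit, no step beyond the scatter and no direction is expected in this assay, and a further reading at the limit is the likeliest result. The expected change is a number no higher from compound 2 to compound 3 (the limit leaves the size open) as estimated here. For compound 3 the estimated value is 5000 nM, with an expected range from 2500 nM to 10000 nM as the outcome.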

Compound 3, half-maximal inhibitory concentration: > 5000 nM
Compound 3 gave a limit, no number; the forecaster's own chance of this, stated with the estimate: 85%; the middle value sits exactly at the limit.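

In this assay compound 3 gives > 5000 nM as its reading, which is a limit and not a number. No step can be read among compound 1, compound 2 and compound 3, since all three share one limit: the limit of > 5000 nM in this assay, at which 3 of the 3 values shown sit. The compounds shown leave open whether trifluoromethoxy, butoxy and tert-butyl differ at all in this read-out.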